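A few compounds are considered here, and "the series" means these few. Any claim that something is new, unique, unknown or untested is made for them only; others in the source may bear on it.

In an ADME assay on microsomes from liver (Homo sapiens) for metabolic stability, read by LC-MS, with NADPH named in the record, with a stated time of 60 min, tested at 1 uM, in the absence of a further agent (a lower number here means that less of the compound is left, a higher number that more of the compound is left), compound 1 (`CSc1ccc(-c2c(C)nc3c(N4CC[C@@H](NC(C)=O)C4)cc(C)nn23)cc1`) gives > 95% as a limit of the assay, not a number. Compound 2 (`CC(=O)N[C@@H]1CCN(c2cc(C)nn3c(-c4nccs4)c(C)nc23)C1`) gives > 95% as a limit too. Compound 3 (`COc1ccc(-c2c(C)nc3c(N4CC[C@@H](NC(=O)C(F)(F)F)C4)cc(C)nn23)cc1OC`) gives > 95% as a limit as well, so no exact number places it. The record so far comes down to one observation (the limit of > 95% in this assay, at which 3 of the 3 values shown sit).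

Compound 4 (`COc1ccc(-c2c(C)nc3c(N4CC[C@@H](NC(=O)Nc5ccccc5)C4)cc(C)nn23)cc1OC`) has not yet been measured. Its difference from compound 3 is this (anilino in place of trifluoromethyl on a carbonyl carbon): anilino in place of trifluoromethyl on a carbonyl carbon, so that ((trifluoromethyl)carbonyl)amino becomes (phenylcarbamoyl)amino.

Among the measured compounds shown here, the only measured step between compounds differing in one place runs (a step that the two limits leave unreadable from compound 1 to compound 2) and cannot be sized. For the measured compounds named here, it also falls on an aromatic carbon, not on a carbonyl carbon, so no measured step speaks directly to this change. The estimate therefore rests mainly on compound 3 and its limit of > 95% as the starting point.

The estimated step of a number at least 3 percentage points lower from compound 3 to compound 4 (that floor lies within the scatter) in this assay is expected to stay within the usual scatter, leaning if at all toward less compound left. For compound 4 the expected value is 92% within an estimated range of 75% to 100% in this read-out.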

Compound 4, percent of the compound remaining: > 95%
Compound 4: no number, only a limit (the forecaster's own chance of this, stated with the estimate: 50%); middle value at least 3 percentage points from the limit.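

Compound 3 and compound 4 each give a limit of the assay rather than a number, so the step between them, anilino in place of trifluoromethyl, cannot be read. What stays open is how much of each compound really remains in this assay and which structural changes would alter that amount, as every result stops at one shared limit: the limit of > 95% in this assay, at which 4 of the 4 values shown sit.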